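Swapping the sulfone ring for an oxane on the chain

The compounds below may be only part of what the source reports. "The series", "measured", "known", "first", "only" and "open" are said of these compounds alone.

Measured compounds:
compound 1 `c1cncc(CNCCCCN(C[C@H]2Cc3ccccc3CN2)[C@H]2CCCc3cccnc32)c1` — 15.3 nM
compound 2 `c1ccc2c(c1)CN[C@@H](CN(CCCCNCC1CCSCC1)[C@H]1CCCc3cccnc31)C2` — 69.6 nM
compound 3 `O=S1(=O)CCC(NCCCCN(C[C@H]2Cc3ccccc3CN2)[C@H]2CCCc3cccnc32)CC1` — 45.5 nM

In a functional assay on cells for antagonist activity at C-X-C chemokine receptor type 4 (Homo sapiens), read by fluorescence and calcium flux, with stated times of 25 min and 90 s (on this read-out higher numbers stand for weaker inhibition and lower numbers for stronger inhibition), compound 3 sits second highest of the three numbers: compound 1 gives a lower number, a 3.0-fold higher number from compound 1 to compound 3 (0.47 log units; beyond the scatter), while compound 2 differs from it only by a 1.5-fold lower number from compound 2 to compound 3 (0.18 log units; within the scatter). Compound 4 `CC(C)(CCN(C[C@H]1Cc2ccccc2CN1)[C@H]1CCCc2cccnc21)CNC1CCOCC1` carries a group of 11 heavy atoms (9 carbon, 1 nitrogen, 1 oxygen; one six-membered non-aromatic ring with 1 hetero atom) in place of a group of 11 heavy atoms (7 carbon, 1 nitrogen, 2 oxygen, 1 sulfur; one six-membered non-aromatic ring with 1 hetero atom), on a saturated chain carbon, two bonds along the chain from an amine nitrogen. The step of a 1.5-fold lower number from compound 2 to compound 3 (0.18 log units; within the scatter) shows that exchanging one saturated six-membered ring for another at this end of the chain left the number within the scatter, whereas a 4.5-fold higher number from compound 1 to compound 2 (0.66 log units; beyond the scatter) and a 3.0-fold higher number from compound 1 to compound 3 (0.47 log units; beyond the scatter) show that moving away from the pyridinyl group costs modestly. As compound 4 keeps a saturated ring, the change is expected to be small, a 1.1-fold higher number from compound 3 to compound 4 (0.04 log units; within the scatter). Compound 4 is therefore estimated at 50 nM, within 15 nM to 160 nM.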

Compound 4, half-maximal inhibitory concentration: 36.3 nM
The estimate for compound 4 lay 1.4-fold (0.14 log units) above the measured number; the measured number falls inside the stated range.
By their numbers in this assay, from the lowest: compound 1; then compounds 4, 3 and 2 (each within the scatter of the next).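

In this assay the entering group, with its oxygen-bearing saturated ring, reads like both sulfur-bearing groups, with a 1.3-fold lower number from compound 3 to compound 4 (0.10 log units; within the scatter) and a 1.9-fold lower number from compound 2 to compound 4 (0.28 log units; within the scatter) at this place on the chain. For the compounds shown here, only the pyridin-3-yl compound stands apart, with a 2.4-fold higher number from compound 1 to compound 4 (0.38 log units; beyond the scatter) as the one step here beyond the scatter, so all three saturated rings now fall on the same side of it. Nothing available explains these steps.
The compounds shown leave open how a piperidine ring or a carboxylic acid at this place would read.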